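A few compounds are considered here, and "the series" means these few. Any claim that something is new, unique, unknown or untested is made for them only; others in the source may bear on it.

In an ADME assay on BJ cells (Homo sapiens), read by MTT assay, with a stated time of 72 h (a higher number here means a weaker inhibitor, a lower number a stronger inhibitor), compound 1 `O=c1[nH]cnc2c1c(-c1cc3ccccc3o1)cn2[C@@H]1O[C@H](CO)[C@@H](O)[C@H]1O` gives 62700 nM as a measured number. Compound 2 `Nc1nc(N)c2c(-c3ccsc3)cn([C@@H]3O[C@H](CO)[C@@H](O)[C@H]3O)c2n1` gives > 100000 nM and this is a limit of the assay. Compound 3 `Cc1nc(N)c2c(-c3ccsc3)cn([C@@H]3O[C@H](CO)[C@@H](O)[C@H]3O)c2n1` gives > 100000 nM and this too is only a limit, so compound 3 has no number of its own. The series shows the limit of > 100000 nM in this assay, at which 2 of the 3 values shown sit, and nothing finer. Compound 4 `C#Cc1cn([C@@H]2O[C@H](CO)[C@@H](O)[C@H]2O)c2nc(C)nc(N)c12` follows with ethynyl in place of thiophen-3-yl on an aromatic carbon as its change, ethynyl in place of thiophen-3-yl on an aromatic carbon. Within the data shown here, the one measured step, a step that the two limits leave unreadable from compound 2 to compound 3, gives no size to carry over. With compound 3 resting on a limit, only a move towards stronger inhibition could be read in this assay and a modest one is expected. The expected value for compound 4 is 50000 nM with a range of 5000 nM to 100000 nM in this assay. The estimated change is an at least 2.0-fold lower number from compound 3 to compound 4 (0.30 log units; that floor lies within the scatter) and a further limit reading would not be a surprise.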

Compound 4, half-maximal inhibitory concentration: > 100000 nM
Compound 4: no number, only a limit (the forecaster's own chance of this, stated with the estimate: 50%); middle value at least 2.0-fold (0.30 log units) away from the limit.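

Among these compounds, compound 3 and compound 4 both rest on a limit in this assay, so no step between them can be read. The compounds shown leave open whether thiophen-3-yl and ethynyl differ at all past that limit.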